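Methyl Next to the Ring Nitrogen, Tested Twice

The source may hold more compounds than are shown below. What is called first, only, known or untested is meant among the compounds shown, and "the series" means these compounds.

Of the compounds shown here, three have been measured in a functional assay on A-375 cells (Homo sapiens) for cytotoxicity, read by MTT assay, with a stated time of 72 h; on this read-out higher numbers stand for weaker inhibition and lower numbers for stronger inhibition. Compound 1 `N/C(=N\NC(=S)N1CCCCCC1)c1ccccn1` gives 740 nM. Compound 3 `N/C(=N\NC(=S)N1CCSCC1)c1ccccn1` gives 760 nM, a value that sits beside that of compound 1 within the usual scatter, so the two cannot be ranked. How the two cores differ is not broken down here. For the measured compounds named here, compound 2 `Cc1cccc(/C(N)=N/NC(=S)N2CCSCC2)n1` gives 1400 nM, and the step of a 1.8-fold higher number from compound 3 to compound 2 (0.27 log units; within the scatter) is the one structural change for which a measured pair exists, described as methyl in place of hydrogen on an aromatic carbon.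

The fourth compound, compound 4 `Cc1cccc(/C(N)=N/NC(=S)N2CCCCCC2)n1`, has not yet been measured. It stands to compound 1 as compound 2 stands to compound 3: the difference is methyl in place of hydrogen on an aromatic carbon. The place lines of the two changes read the same word for word, so this is the same kind of change made on a different core, and it occurs twice among the compounds shown.

Going by the values given here, because the one measured instance of this change gave a 1.8-fold higher number from compound 3 to compound 2 (0.27 log units; within the scatter), a step of about that size is expected in this assay from compound 1 to compound 4, namely a 1.8-fold higher number from compound 1 to compound 4 (0.24 log units; within the scatter). The expectation rests on a single pair, so it is weak, and it cannot be checked against any other pair here. Compound 4 is therefore estimated to give 1300 nM in this assay, with the expected range running from 650 nM to 2600 nM.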

Compound 4, half-maximal inhibitory concentration: 1800 nM
The estimate for compound 4 lay 1.4-fold (0.14 log units) below the measured number, within the range that was stated.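

In this assay, methyl in place of hydrogen on an aromatic carbon, next to the ring nitrogen, gives a 2.4-fold higher number from compound 1 to compound 4 (0.39 log units; beyond the scatter), a modest step that lies beyond the scatter, whereas the earlier step on the other core lay within it. Set side by side, the two steps cannot be told apart: the same change on two cores in this assay, a 1.8-fold higher number (0.27 log units; within the scatter) from compound 3 to compound 2 and a 2.4-fold higher number (0.39 log units; beyond the scatter) from compound 1 to compound 4, 1.3-fold (0.12 log units) apart, within the scatter of two such steps. For the compounds shown here, the change therefore carried from the core of compound 3 to the core of compound 1 with the number moving the same way both times and by a similar amount, but this rests on only two pairs in a single assay, with only one of the two steps beyond the scatter, and it does not show that the step would hold on any other core or why it has this size.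

The compounds shown leave open whether a longer chain such as ethyl, an amine or a chlorine atom on the same aromatic carbon would give a step of similar size on both cores. They also leave open whether the methyl step would appear at all on other cell lines or in another kind of read-out.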